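Removing the methoxy from compound 2: cytotoxicity outlook

The compounds below may be only part of what the source reports. "The series", "measured", "known", "first", "only" and "open" are said of these compounds alone.

Of the compounds shown here, three have been measured in an ADME assay on HEK293 cells (Homo sapiens) for cytotoxicity, read by reporter gene assay and resazurin assay, with a stated time of 48 h; on this read-out higher numbers stand for lower toxicity in this test and lower numbers for higher toxicity in this test. Compound 1 `COc1c(Br)cccc1C(=O)Nc1ccc(Sc2nc3ccccc3s2)c(Cl)c1` gives > 100000 nM, which is the limit of the assay rather than a number. Compound 2 `COc1ccc(Br)cc1C(=O)Nc1ccc(Sc2nc3ccccc3s2)cc1` likewise gives > 100000 nM in this assay, again a limit. Compound 3 `O=C(Nc1ccccc1)c1cc(Br)ccc1O` gives 35000 nM in this assay, a measured number. No two of the measured compounds differ in a single place, so the gap between compound 3 and the other two cannot be traced to one change. Among the compounds with values here, compound 2 thus stands at the limit of > 100000 nM in this assay, at which 2 of the 3 values shown sit, alongside compound 1, with compound 3 the only one giving a numeric value.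

Compound 4 `O=C(Nc1ccc(Sc2nc3ccccc3s2)cc1)c1cccc(Br)c1` has not yet been measured in this assay. It differs from compound 2 by hydrogen in place of methoxy on an aromatic carbon. Within the data shown here, no measured step of this kind exists among the three compounds, so nothing shows how this change moves cytotoxicity. The step of a number no higher from compound 2 to compound 4 (the limit leaves the size open) is therefore expected to be small, lying within the scatter or at most slightly toward higher toxicity. Compound 4 is estimated at 100000 nM, with a range from 40000 nM to 300000 nM, and with a good chance that this assay again reports only a limit.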

Compound 4, half-maximal cytotoxic concentration: 74000 nM
Compound 4: middle estimate off by 1.4-fold (0.13 log units), on the high side, within the range that was stated.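

Hydrogen in place of methoxy on this aromatic carbon, ortho to a large group and para to a bromo group, is the first single change in this series that can be read in this assay and gives an at least 1.3-fold lower number from compound 2 to compound 4 (0.13 log units; that floor lies within the scatter) in that test. With this change, compound 4 gives 74000 nM as a measured number in this assay, so this core now has a numeric reading from which further single changes can be followed. Only the floor of the step is known and it lies within the scatter, so the loss of the methoxy is not shown to raise toxicity, and the true size of the step stays unknown because compound 2 carries only a limit: the limit of > 100000 nM in this assay, at which 2 of the 4 values shown sit.

On these data alone, what an amine, a carboxylic acid or a longer chain such as ethoxy would do on this aromatic carbon stays open. The compounds shown also leave open whether hydrogen in place of methoxy would read the same way on the core of compound 1, where the methoxy and the bromo group sit differently.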